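The source may hold more compounds than are shown below. What is called first, only, known or untested is meant among the compounds shown, and "the series" means these compounds.

Of the compounds shown here, three sharing one core have been measured in a functional assay (QGY7701 cells, Homo sapiens) for inhibition, read by MTT assay, with a stated time of 48 h; on this read-out lower numbers stand for stronger inhibition and higher numbers for weaker inhibition. Compound 1 `COc1ccc2c(=O)c(/C=C/C(=O)Nc3ccccc3)coc2c1` gives 14000 nM, the lowest of the three numbers. Compound 2 `COc1ccc2c(=O)c(/C=C/C(=O)NCc3cccc(F)c3)coc2c1` gives 28600 nM, and compound 3 `COc1ccc2c(=O)c(/C=C/C(=O)NCc3ccccc3F)coc2c1` gives 34000 nM. Both carry a fluorine-bearing benzyl group where compound 1 carries a plain phenyl, and each of them lies beyond the usual scatter from compound 1: a 2.0-fold higher number from compound 1 to compound 2 (0.31 log units; beyond the scatter), and a 2.4-fold higher number from compound 1 to compound 3 (0.39 log units; beyond the scatter). Between the two benzyl compounds, a 1.2-fold higher number from compound 2 to compound 3 (0.08 log units; within the scatter), so where the fluorine sits makes no visible difference.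

Compound 4 `COc1ccc2c(=O)c(/C=C/C(=O)NCc3ccc(C)cc3)coc2c1` is not yet measured. It differs from compound 1 in one place: 4-methylbenzyl in place of phenyl on an amide-type nitrogen. This step resembles the two benzyl steps already seen, with a methyl instead of a fluorine on the ring. Since both of those steps gave modest rises in this assay, a rise of similar size is expected for compound 4, a 2.0-fold higher number from compound 1 to compound 4 (0.30 log units; within the scatter). Compound 4 is therefore estimated at 28000 nM, with a likely range from 14000 nM to 56000 nM.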

Compound 4, half-maximal inhibitory concentration: 10200 nM
For compound 4 the middle estimate is 2.7-fold (0.44 log units) above the measured one, and the stated range ends above it.
By their numbers in this assay, from the lowest: compounds 4 and 1 (each within the scatter of the next); then compounds 2 and 3 (each within the scatter of the next).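

Carrying a benzyl group on the amide-type nitrogen does not by itself go with a higher number in this assay: 4-methylbenzyl in place of phenyl gives a 1.4-fold lower number from compound 1 to compound 4 (0.14 log units; within the scatter) and so leaves compound 4 level with compound 1. What sits on the benzyl ring does count here, since the listed steps give a 2.8-fold lower number from compound 2 to compound 4 (0.45 log units; beyond the scatter) and a 3.3-fold lower number from compound 3 to compound 4 (0.52 log units; beyond the scatter) in this comparison of the methyl-bearing group with each fluorine-bearing one. No measurement at hand offers a reason for these steps.

Each of these steps changes both the ring group and its ring place, so the effect of the methyl cannot be separated from the effect of where it sits. Plain benzyl, 4-fluorobenzyl and 4-methoxybenzyl would help to separate the two, while an amine on the ring remains an open question.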